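Capping the ring amine of compound 2

This account rests on a few compounds, and the source may have more. Where it says the series, first, only, none or still open, it means among the compounds named here.

Among the compounds with values here, in a toxicity assay on MT4 cells (Homo sapiens) for cytotoxicity, read by MTT assay, with a stated time of 7 days (on this read-out higher numbers stand for lower toxicity in this test and lower numbers for higher toxicity in this test), compound 2 (`Cc1cc(C)cc(S(=O)(=O)c2c(C(=O)NC3CC4(CNC4)C3)[nH]c3ccc(Cl)cc23)c1`) gives 28600 nM as the only true number so far. Compound 1 (`Cc1cc(C)cc(S(=O)(=O)c2c(C(=O)NC3CC4(C3)CN(S(C)(=O)=O)C4)[nH]c3ccc(Cl)cc23)c1`) stands at > 233000 nM which is a limit of the assay and not a number. Compound 3 (`Cc1cc(C)cc(S(=O)(=O)c2c(C(=O)NC3CC4(C3)CN(C(=O)OC(C)(C)C)C4)[nH]c3ccc(Cl)cc23)c1`) differs from compound 2 by tert-butoxycarbonyl in place of hydrogen on an amine nitrogen in a ring and so carries tert-butoxycarbonyl in place of hydrogen on an amine nitrogen in a ring. Within the data shown here, one measured step bears on this, the swap of methylsulfonyl for hydrogen on that same nitrogen, which gave an at least 8.1-fold lower number from compound 1 to compound 2 (0.91 log units; beyond the scatter) as its result. Compound 3 again has a group other than hydrogen on the nitrogen, so on the strength of that step a higher number is expected in this assay with its size uncertain. The expected change is a 3.1-fold higher number from compound 2 to compound 3 (0.50 log units; beyond the scatter) and it may fall short of that step. For compound 3 the estimate is 90000 nM with an expected range of 25000 nM to 233000 nM as the likely span.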

Compound 3, half-maximal cytotoxic concentration: > 224000 nM
Compound 3: no number, only a limit; the forecaster's own chance of this, stated with the estimate: 35%; at least 2.4-fold (0.39 log units) between middle value and limit.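

In this assay, the higher number seen on capping this nitrogen is not tied to methylsulfonyl, since tert-butoxycarbonyl in place of hydrogen on the amine nitrogen in the ring also gives an at least 7.8-fold higher number from compound 2 to compound 3 (0.89 log units; beyond the scatter). Compound 3 reads only as a limit of the assay and not as a number: the limit of > 224000 nM in this assay, at which 1 of the 3 values shown sits. With two different groups now tested on that nitrogen, compound 2, with hydrogen there, is the only one of the three with a true number, and the step from compound 1 to compound 3 cannot be read, since both values are limits.

The compounds shown leave open whether an acetyl or a plain methyl group on the same nitrogen would also give a higher number than hydrogen. They also leave open how far past their limits compound 1 and compound 3 truly lie.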